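Amide chain extension on the shared core, compound 4

The source may hold more compounds than are shown below. What is called first, only, known or untested is meant among the compounds shown, and "the series" means these compounds.

For the measured compounds named here, compound 1 `CNC(=O)c1cc(Oc2ccc(NC(=O)c3cc4cccnc4n(-c4ccc(Br)cc4)c3=O)cc2)ccn1` is the only member of the series with a number in a functional assay on U-87MG ATCC cells for antiproliferative activity against U-87 MG (Homo sapiens), read by MTT assay, with a stated time of 72 h; a higher number here means a weaker inhibitor, a lower number a stronger inhibitor; there compound 1 gives 15000 nM. Going by the values given here, compound 2 `CNC(=O)c1cc(Oc2ccc(NC(=O)c3cc4cccnc4n(-c4ccc(Br)cc4F)c3=O)cc2)ccn1` and compound 3 `CNC(=O)c1cc(Oc2ccc(NC(=O)c3cc4cccnc4n(-c4ccc(F)c(Cl)c4)c3=O)cc2)ccn1`, which differ from compound 1 elsewhere on the structure, carry no number: in this assay compound 2 reads "not determined" (no result reported) and compound 3 reads "not determined" (no result reported), so no step between measured compounds can be drawn. Compound 4 `CCCNC(=O)c1cc(Oc2ccc(NC(=O)c3cc4cccnc4n(-c4ccc(Br)cc4)c3=O)cc2)ccn1` differs from compound 1 only by ethyl in place of hydrogen on a saturated chain carbon bound to an amide-type nitrogen. No comparable change is measured within the set, so only a small shift, if any, is expected, in no direction that would exceed the scatter. The step of a 1.3-fold lower number from compound 1 to compound 4 (0.10 log units; within the scatter) is estimated to stay within that scatter. Compound 4 is expected to give 12000 nM in this assay, between 4000 nM and 40000 nM.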

Compound 4, half-maximal inhibitory concentration: 5190 nM
Estimate against measurement, compound 4: 2.3-fold (0.36 log units) above; low and high end bracket the measured number.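

Going from methylcarbamoyl to propylcarbamoyl gives a 2.9-fold lower number from compound 1 to compound 4 (0.46 log units; beyond the scatter) in this assay and this is the first measured step in the series. It shows that this position accepts added chain length and that the number responds to it beyond the scatter. Nothing at hand bears on the reason for this shift.

A single step leaves open whether a longer chain such as butyl, a branched chain or a terminal amine would move the number further. Compound 2 and compound 3 carry no number, so their changes elsewhere on the structure cannot be read.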